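From an Alkenyl Chain to a Cyanophenyl Ring

This account rests on a few compounds, and the source may have more. Where it says the series, first, only, none or still open, it means among the compounds named here.

Compound 1 `COc1cc(OC)c(-c2coc3cc(OCC=C(C)C)ccc3c2=O)cc1OC` gives 680 nM in a functional assay on HCT-116 cells (Homo sapiens) for antiproliferative activity, read by MTT assay, with a stated time of 24 h (a lower number here means a stronger inhibitor, a higher number a weaker inhibitor), the lowest of the two plain numbers shown. Compound 2 `COc1cc(OC)c(-c2coc3cc(OCc4ccc(Br)cc4)ccc3c2=O)cc1OC` gives 1980 nM. For compound 3 `COc1cc(OC)c(-c2coc3cc(OCc4ccc([N+](=O)[O-])cc4)ccc3c2=O)cc1OC` the assay reports only a limit, > 10000 nM (the limit of > 10000 nM in this assay, at which 1 of the 3 values shown sits). Compound 4 `COc1cc(OC)c(-c2coc3cc(OCc4ccccc4C#N)ccc3c2=O)cc1OC` has not been measured; it differs from compound 1 in one place: 2-cyanophenyl in place of 2-methylprop-1-en-1-yl on a saturated chain carbon bound to an oxygen on an aromatic ring. Two measured steps replace the same chain with a substituted phenyl ring: a 2.9-fold higher number from compound 1 to compound 2 (0.46 log units; beyond the scatter), and an at least 14-fold higher number from compound 1 to compound 3 (1.16 log units; beyond the scatter). Both raise the number, and the nitro-bearing ring does so more than the bromo-bearing one, as an at least 5.0-fold higher number from compound 2 to compound 3 (0.70 log units; beyond the scatter) shows. A cyanophenyl ring is therefore expected to weaken inhibition as well, by a modest to large step, a 5.9-fold higher number from compound 1 to compound 4 (0.77 log units; beyond the scatter). Compound 4 is estimated at 4000 nM, within 1500 nM to 12000 nM.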

Compound 4, half-maximal inhibitory concentration: > 10000 nM
Compound 4 gave a limit, no number; the forecaster's own chance of this, stated with the estimate: 35%; at least 2.5-fold (0.39 log units) between middle value and limit.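

At this position, the 2-cyanophenyl ring gives an at least 14-fold higher number from compound 1 to compound 4 (1.16 log units; beyond the scatter), and replacing the 4-bromophenyl ring with it gives an at least 5.0-fold higher number from compound 2 to compound 4 (0.70 log units; beyond the scatter). A ring carrying a nitrile therefore joins the nitro-bearing ring in compound 3, and of the three substituted rings only the bromo-bearing one in compound 2 keeps a plain number. The step between compound 3 and compound 4 cannot be read, with both compounds at a limit: the limit of > 10000 nM in this assay, at which 2 of the 4 values shown sit.

Still open, going by these compounds, is how far beyond that limit these two compounds lie. Also open, on these data alone, is whether an unsubstituted benzyl group or a longer alkenyl chain would stay close to compound 1.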